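Swapping Cyclohexyl for Trifluoropropyl: Expected Liver-Cell Toxicity

A few compounds are considered here, and "the series" means these few. Any claim that something is new, unique, unknown or untested is made for them only; others in the source may bear on it.

Four compounds built on one shared core were examined in an ADME assay on Huh-7 cells (Homo sapiens) for cytotoxicity, with a stated time of 72 h; on this read-out higher numbers stand for lower toxicity in this test and lower numbers for higher toxicity in this test. Compound 1, `CC(C)CCn1nc(-c2cccs2)c(O)c(C2=NS(=O)(=O)c3cc(S(C)(=O)=O)ccc3N2)c1=O`, has "not determined" (no result reported) in this assay. Compound 2, `CS(=O)(=O)Nc1ccc2c(c1)S(=O)(=O)N=C(c1c(O)c(-c3ccc(Cl)s3)nn(CCC3CC3)c1=O)N2`, gives only a limit in this assay, > 33000 nM. Compound 3, `CC(C)CCn1nc(C2CCCCC2)c(O)c(C2=NS(=O)(=O)c3cc(NS(C)(=O)=O)ccc3N2)c1=O`, likewise gives a limit in this assay, > 1000 nM, which places it at the limit of > 1000 nM in this assay, at which 1 of the 3 values shown sits. One entry is not determined and the other two are limits. Among the measured compounds shown here, no step between measured compounds can be computed, and compound 3 cannot be ranked against any other compound on these numbers; all that can be said is that it showed no measurable toxicity up to its limit.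

Compound 4, `CC(C)CCn1nc(CCC(F)(F)F)c(O)c(C2=NS(=O)(=O)c3cc(NS(C)(=O)=O)ccc3N2)c1=O`, differs from compound 3 in a single place: 3,3,3-trifluoropropyl in place of cyclohexyl on an aromatic carbon. For the measured compounds named here, with no measured step to build on, the exchange of cyclohexyl for 3,3,3-trifluoropropyl is expected to change toxicity by no more than the usual scatter, so the step that the limit leaves unreadable from compound 3 to compound 4 is estimated to be small and without a clear direction. Compound 4 is therefore expected to give about 20000 nM in this assay, within an estimated range from 3000 nM to 100000 nM, quite possibly reported again as a limit rather than as a number.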

Compound 4, half-maximal cytotoxic concentration: > 33000 nM
Compound 4: a limit, no number; the forecaster's own chance of this, stated with the estimate: 70%; middle value at least 1.6-fold (0.21 log units) from the limit.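

In this assay, compound 3 and compound 4 are both reported only as limits, not as numbers, and no step can be read between them. The compounds shown leave open whether exchanging cyclohexyl for 3,3,3-trifluoropropyl changes toxicity in this assay at all, and at what concentration, if any, either compound turns toxic.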